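A Fluorine Added to a Pair Sitting at the Limit

The compounds below may be only part of what the source reports. "The series", "measured", "known", "first", "only" and "open" are said of these compounds alone.

Two closely related hydrazones have been examined in a toxicity assay on HCT-116 cells (Homo sapiens) for cytotoxicity, read by MTT assay; on this read-out higher numbers stand for weaker inhibition of growth and lower numbers for stronger inhibition of growth. Compound 1 `C/C(=N\Nc1nc(-c2ccc(F)cc2)cs1)c1sc(C)nc1C` gives > 100 ug/mL, which is a limit of the assay and not a number. Compound 2 `C/C(=N\Nc1nc(-c2ccccc2)cs1)c1sc(-c2ccccc2)nc1C` gives > 100 ug/mL, again a limit rather than a measured number. Compound 2 thus stands at the same edge at which every value seen so far sits: the limit of > 100 ug/mL in this assay, at which 2 of the 2 values shown sit. Going by the values given here, no step between measured compounds can be drawn from these two.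

Compound 3 `C/C(=N\Nc1nc(-c2ccc(F)cc2)cs1)c1sc(-c2ccccc2)nc1C` differs from compound 2 by a single change, (fluoro in place of hydrogen on an aromatic carbon), that is fluoro in place of hydrogen on an aromatic carbon. Compound 1 already carries this 4-fluorophenyl group and also gives only a limit in this assay. For compound 3 no movement beyond the usual scatter is expected in this assay, and the step that the limit leaves unreadable from compound 2 to compound 3 is estimated to leave it at the same edge. Compound 3 is expected to give about 150 ug/mL, within 60 ug/mL to 400 ug/mL, most likely reported once more as a limit.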

Compound 3, concentration for 50% growth inhibition: > 100 ug/mL
Compound 3: no number, only a limit; the forecaster's own chance of this, stated with the estimate: 85%; the middle value does not contradict the limit.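

Compound 3 gives only a limit, as do compound 1 and compound 2, so no step from either of them to compound 3 can be read: the limit of > 100 ug/mL in this assay, at which 3 of the 3 values shown sit.

The compounds shown leave open whether fluoro in place of hydrogen, or phenyl in place of methyl, changes growth inhibition at all, as none of them gives a number.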